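One more ring on the sulfonamide nitrogen

The source may hold more compounds than are shown below. What is called first, only, known or untested is meant among the compounds shown, and "the series" means these compounds.

compound 1 `COc1cc(C(F)(F)F)ccc1-c1cccc2cc(S(=O)(=O)Nc3ccncn3)ccc12`: 27 10^-6 cm/s
compound 2 `COc1cc(C(F)(F)F)ccc1-c1cccc2cc(S(=O)(=O)Nc3ncccn3)ccc12`: 36 10^-6 cm/s
compound 3 `COc1cc(C(F)(F)F)ccc1-c1cccc2cc(S(=O)(=O)Nc3cncs3)ccc12`: 28 10^-6 cm/s

In an ADME assay on MDCK cells (Canis lupus familiaris) for permeability (a lower number here means that the compound crosses the layer more slowly, a higher number that the compound crosses the layer faster), compound 1 stands level with the other two compounds, since neither of its steps leaves the scatter. The next compound is compound 4 `COc1cc(C(F)(F)F)ccc1-c1cccc2cc(S(=O)(=O)Nc3cscn3)ccc12`, and the change is 1,3-thiazol-4-yl in place of pyrimidin-4-yl on a sulfonamide nitrogen. Among the measured compounds shown here, the steps that bear on it are small: 1,3-thiazol-5-yl gives a 1.0-fold higher number from compound 1 to compound 3 (0.02 log units; within the scatter), and pyrimidin-2-yl gives a 1.3-fold higher number from compound 1 to compound 2 (0.12 log units; within the scatter). The step between those two is a 1.3-fold lower number from compound 2 to compound 3 (0.11 log units; within the scatter). No step beyond the scatter is therefore expected in this assay. The expected step is a 1.0-fold higher number from compound 1 to compound 4 (0.02 log units; within the scatter). For compound 4 the estimate is 28 10^-6 cm/s, with an expected range of 17 10^-6 cm/s to 45 10^-6 cm/s.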

Compound 4, apparent permeability: 27 10^-6 cm/s
Estimate against measurement, compound 4: 1.0-fold (0.02 log units) above, and the stated range covers the measured number.
By their numbers in this assay, from the lowest: compounds 1, 4, 3 and 2 (each within the scatter of the next).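

In this assay, the five-membered 1,3-thiazol-4-yl ring on the sulfonamide nitrogen, in place of the six-membered pyrimidin-4-yl ring, gives no change at the digits printed from compound 1 to compound 4 (within the scatter). The new ring also stays within the scatter of the other two groups, with a 1.0-fold lower number from compound 3 to compound 4 (0.02 log units; within the scatter) and a 1.3-fold lower number from compound 2 to compound 4 (0.12 log units; within the scatter), so this change of ring size and of thiazole attachment leaves the read-out level. Nothing measured here explains this.

All four compounds carry an aromatic ring with two hetero atoms at this position. From the compounds shown here alone, whether a longer chain, or a ring bearing an amine or a carboxylic acid, would stay level remains open.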